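This account rests on a few compounds, and the source may have more. Where it says the series, first, only, none or still open, it means among the compounds named here.

Measured so far in a functional assay on K562 cells (Homo sapiens) for antiproliferative activity, read by trypan blue exclusion, with a stated time of 48 h, tested at 10 uM; on this read-out higher numbers stand for more inhibition of growth at the one concentration tested and lower numbers for less inhibition of growth:
Compound 1 `Cc1ccc(NC(=O)/C=C/c2ccccc2)c(C(N)=O)c1`: 65.4%
Compound 2 `NC(=O)c1cc(Cl)ccc1NC(=O)/C=C/c1cccc(Br)c1`: 27%
Compound 3 `NC(=O)c1cc(Br)ccc1NC(=O)/C=C/c1ccccc1Cl`: 59%

Compound 3, at 59%, cannot be told apart from compound 1, at 65.4%, since the gap between them lies within the scatter of repeated measurements. Compound 2, at 27%, lies below compound 3 by a margin beyond the scatter, so compound 3 sits with the better of the two groups in this small set.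

The next compound, compound 4 `NC(=O)c1cc(Br)ccc1NC(=O)/C=C/c1ccccc1Br`, keeps the structure of compound 3 except for one change: bromo in place of chloro on an aromatic carbon. In words, this is bromo in place of chloro on an aromatic carbon, or 2-chlorophenyl to 2-bromophenyl.

Among the measured compounds shown here, no two measured compounds differ in only one place, so the data offer no direct example of this swap. The low value of compound 2, 27%, shows that numbers in this set can move widely, although that compound differs from the others in more than one place. The expectation therefore rests on compound 3, at 59%, the closest measured structure, and the range is kept wide. No step beyond the scatter is expected in this assay, and the estimated a number 1 percentage points lower from compound 3 to compound 4 (within the scatter) is small. Compound 4 is expected to give 58%, with an estimated range from 42% to 72%.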

Compound 4, percent growth inhibition at one concentration: 46.2%
Compound 4: the middle estimate sits 11.8 percentage points above what was measured, within the range that was stated.
By their numbers in this assay, from the lowest: compound 2; then compound 4; then compounds 3 and 1 (each within the scatter of the next).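

Among the compounds shown here, this pair gives the first direct reading of a single change in this set: in this assay, bromo in place of chloro on an aromatic carbon, ortho to a large group, gives a number 12.8 percentage points lower from compound 3 to compound 4 (beyond the scatter). One halogen cannot simply stand in for the other at this place on this read-out, even though no ring enters or leaves, the counts of hydrogen-bond donors and acceptors stay the same, and no net charge appears. Nothing available here bears on why the two compounds differ, so the reason remains unknown.

The compounds shown leave open how fluoro, methoxy, an amine or a carboxylic acid at this same place would read, and so whether growth inhibition here follows any trend across groups or is particular to these two halogens. A single pair also cannot tell whether bromo in place of chloro would give a step of similar size on a different substitution pattern of the shared core.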